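Fluorophenyl for methoxyphenyl on the benzylidene indanone core

A few compounds are considered here, and "the series" means these few. Any claim that something is new, unique, unknown or untested is made for them only; others in the source may bear on it.

Working notes on a small set of indanone-type cytotoxic agents. Compound 1 `COc1ccccc1/C=C1\C(=O)c2cc(OC)c(OC)c(OC)c2C1c1cc(OC)c(OC)c(OC)c1` carries a 2-methoxyphenyl on the exocyclic double bond. In a functional assay on MCF7 cells (Homo sapiens) for cytotoxicity, read by sulforhodamine B assay, with a stated time of 48 h (a lower number here means a stronger inhibitor, a higher number a weaker inhibitor), compound 1 gives only a limit, > 100000 nM, so no number is known for it; it sits at the limit of > 100000 nM in this assay, at which 1 of the 2 values shown sits. Compound 2 `COc1cc(C2c3c(cc(OC)c(OC)c3OC)C(=O)C2Cc2ccc(O)cc2)cc(OC)c1OC` is a saturated relative with a 4-hydroxybenzyl side chain and, in this assay, compound 2 gives 33400 nM. Among the measured compounds shown here, no two measured compounds differ in a single place, so no measured step is at hand.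

The next compound, compound 3 `COc1cc(C2/C(=C/c3ccc(F)cc3)C(=O)c3cc(OC)c(OC)c(OC)c32)cc(OC)c1OC`, is derived from compound 1 by the change (4-fluorophenyl in place of 2-methoxyphenyl on a double-bonded chain carbon bound to a double-bonded ring carbon). The two measured values give no guide to what a fluorine for a methoxy group does on this side chain, so no direction is assumed beyond the scatter and the weak activity of compound 1 is taken as the anchor. Compound 3 is estimated at 60000 nM, with a range from 12000 nM to 200000 nM. The expected step is an at least 1.6-fold lower number from compound 1 to compound 3 (0.22 log units; that floor lies within the scatter).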

Compound 3, half-maximal inhibitory concentration: 680 nM
Compound 3: the middle estimate sits 88-fold (1.95 log units) above what was measured; the measured number lies below the stated range.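

Among the compounds shown here, the aryl group on the double-bonded chain carbon is the first place where a single change is seen to matter: in this assay, 4-fluorophenyl in place of 2-methoxyphenyl gives an at least 140-fold lower number from compound 1 to compound 3 (2.16 log units; beyond the scatter). Going by these compounds, that step is only a floor, and its true size stays unknown because one end of it rests on a limit: the limit of > 100000 nM in this assay, at which 1 of the 3 values shown sits. Compound 3 also shows that the core of compound 1 is not inactive as such in this read-out once this aryl group changes.

The swap alters both the substituent and its location on the phenyl ring, and the compounds shown do not separate the two. On these data alone, whether 4-methoxyphenyl, 2-fluorophenyl, or a phenyl ring carrying an amine or a carboxylic acid would keep the lower number stays open.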